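Alkyl chain shortening across two related cores

A few compounds are considered here, and "the series" means these few. Any claim that something is new, unique, unknown or untested is made for them only; others in the source may bear on it.

Compound 1 `CCCCc1nnc(O)n2c(CCC)nc(C)c12` sets the reference. In a functional assay for inhibition, with Homo sapiens as the target (a lower number here means a stronger inhibitor, a higher number a weaker inhibitor), compound 1 reaches only a limit of the assay, > 48000 nM. Compound 2 `CCCc1nnc(O)n2c(CCC)nc(C)c12` differs from it by hydrogen in place of methyl on a saturated chain carbon, three bonds along the chain from an aromatic carbon, and in this assay compound 2 gives 16000 nM. That single change produced an at least 3.0-fold lower number from compound 1 to compound 2 (0.47 log units; beyond the scatter).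

Compound 3 `CCCc1nc(C)c2c(-c3ccccc3)nnc(O)n12` stands on a changed core, differing from compound 1 by phenyl in place of butyl on an aromatic carbon. In this assay compound 3 again stops at a limit, > 48000 nM. Against compound 2 this reads as an at least 3.0-fold higher number from compound 2 to compound 3 (0.47 log units; beyond the scatter), whereas a step that the two limits leave unreadable from compound 1 to compound 3 because the limit of > 48000 nM in this assay, at which 2 of the 3 values shown sit, holds both ends of that pair.

Compound 4 `CCc1nc(C)c2c(-c3ccccc3)nnc(O)n12` is not yet measured. It differs from compound 3 by hydrogen in place of methyl on a saturated chain carbon, two bonds along the chain from an aromatic carbon. For the measured compounds named here, this is the same kind of change as the one from compound 1 to compound 2, but not the same: there the place was three bonds along the chain from an aromatic carbon, here it is two bonds along the chain from an aromatic carbon. In this assay the expected step is an at least 1.2-fold lower number from compound 3 to compound 4 (0.07 log units; that floor lies within the scatter), resting on an at least 3.0-fold lower number from compound 1 to compound 2 (0.47 log units; beyond the scatter) while compound 3 sits at a limit, so the starting point itself is not known. For compound 4 a value of about 40000 nM is estimated, with a likely range from 12000 nM to 120000 nM.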

Compound 4, half-maximal inhibitory concentration: > 48000 nM
Compound 4 gave a limit, no number (the forecaster's own chance of this, stated with the estimate: 60%); middle value at least 1.2-fold (0.07 log units) away from the limit.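

No step can be read between compound 3 and compound 4, as both stop at a limit in this assay: the limit of > 48000 nM in this assay, at which 3 of the 4 values shown sit.

The compounds shown leave open whether propyl to ethyl on the core of compound 3 changes the result in this assay at all, and in which direction.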